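Biphenyl thromboxane antagonists: removing the methanesulfonamido group

This account rests on a few compounds, and the source may have more. Where it says the series, first, only, none or still open, it means among the compounds named here.

Of the compounds shown here, two have numbers so far. Compound 1 `CC(=O)NCc1ccccc1-c1ccc(COC2CC[C@H](N3CCCCCC3)[C@H]2OC/C=C\CCC(=O)O)cc1` gives 126 nM in a functional assay for antagonist activity at thromboxane A2 receptor (Rattus norvegicus); a lower number here means tighter binding, a higher number weaker binding. Compound 2 `CS(=O)(=O)Nc1cccc(-c2ccc(COC3CC[C@H](N4CCCCCC4)[C@H]3OC/C=C\CCC(=O)O)cc2)c1` gives 50.1 nM in this assay, the lowest of the two numbers, with compound 1 the nearest. Going by the values given here, the one step between them, a 2.5-fold lower number from compound 1 to compound 2 (0.40 log units; beyond the scatter), is modest but beyond the scatter, showing that the substituent on the outer ring of the biphenyl moves the dissociation constant by a measurable amount.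

Compound 3 `O=C(O)CC/C=C\CO[C@H]1C(OCc2ccc(-c3ccccc3)cc2)CC[C@@H]1N1CCCCCC1` is not yet measured. It differs from compound 2 in one place: hydrogen in place of methanesulfonamido on an aromatic carbon. Among the compounds with values here, no step among the measured compounds removes a substituent from this ring outright, so the direction rests only on the indication that compound 2 with its methanesulfonamido group sits below compound 1. The loss of the group is expected to cost some of that margin, giving an estimated step of a 2.6-fold higher number from compound 2 to compound 3 (0.41 log units; beyond the scatter). For compound 3 the expected dissociation constant is 130 nM, with a likely range from 45 nM to 400 nM.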

Compound 3, dissociation constant: 25.1 nM
Compound 3: the middle estimate sits 5.2-fold (0.71 log units) above what was measured, outside the stated range (below it).
By their numbers in this assay, from the lowest: compounds 3 and 2 (each within the scatter of the next); then compound 1.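

In this assay, a 2.0-fold lower number from compound 2 to compound 3 (0.30 log units; within the scatter), which lies within the scatter, so the plain phenyl of compound 3 and the 3-(methanesulfonamido)phenyl of compound 2 cannot be told apart, and a number of this size does not need the methanesulfonamido group on this aromatic carbon. The other new step, with a 5.0-fold lower number from compound 1 to compound 3 (0.70 log units; beyond the scatter), is beyond the scatter, so the earlier gap between the two substituted compounds now reads as a penalty that goes with the acetamidomethyl group rather than a gain brought by methanesulfonamido. Nothing measured on these compounds gives a reason for either step.

The compounds shown leave open whether any substituent on this ring can bring the number clearly under that of compound 3, since only two substituents stand against hydrogen here and neither does so. A small group such as methyl, fluorine or methoxy, or a carboxylic acid or an amine, at this same carbon would test whether the ring tolerates substitution in general or only the methanesulfonamido group.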